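The compounds below may be only part of what the source reports. "The series", "measured", "known", "first", "only" and "open" are said of these compounds alone.

Two related compounds have been followed in an ADME assay on the whole organism for pharmacokinetics, with Homo sapiens as the target, with a stated time of 21 days, at a dose of 15 mg by the oral route; on this read-out higher numbers stand for higher exposure at the dose given and lower numbers for lower exposure. Compound 1 (`CO[C@@H]1[C@H](OC(=O)N[C@@H](C(N)=O)C(C)(C)O)CC[C@]2(CO2)[C@H]1[C@@]1(C)O[C@@H]1C[C@@H]1OC1(C)C`) gives 7.45 nM, while compound 2 (`CO[C@@H]1[C@H](OC(=O)N[C@@H](C(N)=O)C(C)C)CC[C@]2(CO2)[C@H]1[C@@]1(C)O[C@@H]1C[C@H]1OC1(C)C`) gives 98.5 nM, the higher of the two numbers and a gap beyond the usual scatter of repeat measurements. Compound 3 (`CO[C@@H]1[C@H](OC(=O)N[C@@H](C(N)=O)C(C)(C)O)CC[C@]2(CO2)[C@H]1[C@@]1(C)O[C@@H]1C[C@H]1OC1(C)C`) is compound 2 with one alteration, hydroxy in place of hydrogen on a saturated chain carbon bound to three saturated chain carbons, which turns isopropyl into 1-hydroxy-1-methylethyl. Going by the values given here, no measured pair shows this change on its own, so the guidance is thin. Compound 1 also carries 1-hydroxy-1-methylethyl and stands at 7.45 nM, so a drop beyond the scatter is expected, though not necessarily one reaching that low. The estimated move is a 4.9-fold lower number from compound 2 to compound 3 (0.69 log units; beyond the scatter). For compound 3 the expected value is 20 nM, with a likely range from 6 nM to 70 nM.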

Compound 3, maximal plasma concentration: 8.98 nM
Compound 3: the middle estimate sits 2.2-fold (0.35 log units) above what was measured, within the range that was stated.
By their numbers in this assay, from the lowest: compounds 1 and 3 (each within the scatter of the next); then compound 2.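

In this assay, placing hydroxy on a saturated chain carbon bound to three saturated chain carbons gives an 11-fold lower number from compound 2 to compound 3 (1.04 log units; beyond the scatter), so this change, now seen on its own, is a large one on this read-out. The second step gives a 1.2-fold higher number from compound 1 to compound 3 (0.08 log units; within the scatter), so the read-out does not separate these two hydroxy compounds. That makes the drawn configuration at this one saturated ring carbon a change without a visible effect here, and the comparison is a clean one, resting on this: the fact that compounds 1 and 3 differ only in the configuration as drawn

The compounds shown leave open whether another group on the same carbon, such as an amine or a methoxy group, would lower the number as hydroxy does. They also leave open whether the same stereocentre would matter with isopropyl in place of 1-hydroxy-1-methylethyl.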